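Carboxyl-bearing amides on a shared benzofuran-type core

This account rests on a few compounds, and the source may have more. Where it says the series, first, only, none or still open, it means among the compounds named here.

Measured so far:
compound 1 `CC(C)(NC(=O)c1cc(F)cc2cc(-c3ccc(Cl)cc3)oc12)C(N)=O` — > 10000 nM
compound 2 `C[C@H](NC(=O)c1cc(F)cc2cc(-c3ccc(Cl)cc3)oc12)C(=O)O` — 4440 nM

Within the data shown here, in an assay on isolated protein for inhibition of endoplasmic reticulum aminopeptidase 1 (Homo sapiens), with stated times of 15 min and 20 min (a lower number here means a stronger inhibitor, a higher number a weaker inhibitor), compound 2 gives 4440 nM, the only actual number among the two results. Compound 1 reaches only the assay limit, > 10000 nM, which is the limit of > 10000 nM in this assay, at which 1 of the 2 values shown sits, and not a number. The step of an at least 2.2-fold lower number from compound 1 to compound 2 (0.35 log units; beyond the scatter) is therefore known only as a lower bound.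

Compound 3 `O=C(NC1(C(=O)O)CCCCC1)c1cc(F)cc2cc(-c3ccc(Cl)cc3)oc12` keeps the carboxylic acid of compound 2 and alters the carbon bearing it: 1-carboxycyclohexyl in place of 1-carboxyethyl on an amide-type nitrogen. Among the measured compounds shown here, the one measured step concerns the exchange of a carbamoyl group for a carboxyl group, not the size of the alkyl part, so it bears on the change to compound 3 only in showing that the carboxyl-bearing amides are the ones yielding a number in this assay. For the measured compounds named here, no measured pair tells how a larger alkyl group on that nitrogen behaves. The expectation for the step of a 1.3-fold lower number from compound 2 to compound 3 (0.10 log units; within the scatter) is therefore one of no change beyond the scatter, with wide uncertainty in both directions. Compound 3 is estimated at 3500 nM, within 900 nM to 14000 nM.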

Compound 3, half-maximal inhibitory concentration: 34 nM
Beside the measured number, compound 3's estimate is 100-fold (2.01 log units) above it, outside the stated range (below it).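

In this assay, the group on the amide-type nitrogen can shift the number strongly even with the carboxylic acid retained: 1-carboxycyclohexyl in place of 1-carboxyethyl gives a 130-fold lower number from compound 2 to compound 3 (2.12 log units; beyond the scatter). The earlier step had set a carbamoyl-bearing group against a carboxyl-bearing one, so it gave no measure of what the carbon bearing the acid contributes; this step shows that this carbon is a sensitive point in the series. Set against the first compound, the same group gives an at least 290-fold lower number from compound 1 to compound 3 (2.46 log units; beyond the scatter), a lower bound only, as the value of compound 1 is a limit and not a number: the limit of > 10000 nM in this assay, at which 1 of the 3 values shown sits.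

The change to compound 3 brings in a six-membered ring, more carbon atoms and the loss of the defined stereocentre all at once, and the compounds shown cannot separate these, leaving open how an open-chain 1-carboxy-1-methylethyl group or a smaller 1-carboxycyclopentyl group would compare. They also leave open whether the cyclohexyl ring would carry the same weight with a primary amide in place of the carboxylic acid, as in a 1-carbamoylcyclohexyl group.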